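Pyrazoline series: styryl in place of 2-chlorophenyl

A few compounds are considered here, and "the series" means these few. Any claim that something is new, unique, unknown or untested is made for them only; others in the source may bear on it.

Compound 1 `Cc1cc(O)c(C2=NN(c3ccc(S(N)(=O)=O)cc3)C(c3ccccc3O)C2)cc1Cl` carries a 2-hydroxyphenyl group on the saturated ring carbon of the shared core. In a functional assay on SNB-19 cells (Homo sapiens) for antiproliferative activity, with a stated time of 48 h (on this read-out lower numbers stand for stronger inhibition of growth and higher numbers for weaker inhibition of growth), compound 1 gives 4330 nM. Compound 2 `Cc1cc(O)c(C2=NN(c3ccc(S(N)(=O)=O)cc3)C(c3ccccc3Cl)C2)cc1Cl` has chloro in place of hydroxy there, and in this assay compound 2 gives 3540 nM; the change amounts to a 1.2-fold lower number from compound 1 to compound 2 (0.09 log units; within the scatter). For the measured compounds named here, on the two numbers so far, compound 2 stands lowest, with compound 1 nearest and within the scatter of it. Compound 3 `Cc1cc(O)c(C2=NN(c3ccc(S(N)(=O)=O)cc3)C(/C=C/c3ccccc3)C2)cc1Cl` differs from compound 2 by 2-phenylethenyl in place of 2-chlorophenyl on a saturated ring carbon. Going by the values given here, the one measured step concerns a different kind of change on that same carbon and lay within the scatter, so it gives no direction for the present change; no step with a 2-phenylethenyl group exists. A number close to that of compound 2 is therefore expected for compound 3 in this assay, the step being estimated as a 1.1-fold higher number from compound 2 to compound 3 (0.05 log units; within the scatter), no more than the scatter. The estimate for compound 3 is 4000 nM, expected to fall between 1500 nM and 11000 nM.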

Compound 3, concentration for 50% growth inhibition: 7840 nM
Compound 3: the middle estimate sits 2.0-fold (0.29 log units) below what was measured, within the range that was stated.
By their numbers in this assay, from the lowest: compounds 2, 1 and 3 (each within the scatter of the next, the first and the last beyond it).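

In this assay this saturated ring carbon now gives its first step beyond the scatter (a 2.2-fold higher number from compound 2 to compound 3 (0.35 log units; beyond the scatter)), a modest one, so the group it bears can shift the number. The same 2-phenylethenyl group set against 2-hydroxyphenyl stays within the scatter (a 1.8-fold higher number from compound 1 to compound 3 (0.26 log units; within the scatter)), so the separation holds only for the pair of compound 2 and compound 3, and compound 1 cannot be told apart from either. Nothing available accounts for the step.

Open, as far as these compounds go, is whether the double bond of the 2-phenylethenyl group or the chlorine leaving with 2-chlorophenyl matters here, which a 2-phenylethyl chain on this carbon would help to separate. Also open, from the compounds shown here alone, is how this carbon responds to a group without an aromatic ring, such as an aminomethyl group or a carboxylic acid.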